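The source may report more compounds than this note shows. Statements on the series, on what has been measured and on what is new or still open speak of the compounds shown alone.

The measured compounds in the study:

compound 1 `C#Cc1sc(-c2ccc(F)cc2)nc1C(=O)OCC` — in a functional assay on HCT-116 cells (Homo sapiens) for cytotoxicity, with a stated time of 3 days (on this read-out higher numbers stand for weaker inhibition and lower numbers for stronger inhibition), compound 1 reaches only the limit of the measurement, > 40000 nM
compound 2 `C=Cc1nc(C(=O)OCC)cs1` — in this assay compound 2 reaches only the limit, > 40000 nM
compound 3 `C#Cc1nc(C(=O)OCC)cs1` — in this assay compound 3 reaches only the limit, > 40000 nM

The study turns on one structural change, seen twice among the compounds shown: vinyl in place of ethynyl on an aromatic carbon. Between the two measured partners this change gave a step that the two limits leave unreadable from compound 3 to compound 2, since both values sit at a limit and no number can be read out of them. Among the compounds with values here, that is the whole of the measured evidence: the limit of > 40000 nM in this assay, at which 3 of the 3 values shown sit, and so no step anywhere in the set has a readable size.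

Compound 4 `C=Cc1sc(-c2ccc(F)cc2)nc1C(=O)OCC` is the unmeasured partner of compound 1. The difference between the two is vinyl in place of ethynyl on an aromatic carbon. The difference between the core of compound 1 and the core of compound 3 is not broken down here. The place of the change is not the same word for word in the two pairs: in compound 3 the carbon sits next to the ring nitrogen, next to the ring sulfur, two ring bonds from the ring atom that bears a group of 5 heavy atoms, while in compound 1 it sits next to the ring sulfur, next to the ring atom that bears an ethoxycarbonyl group, two ring bonds from the ring nitrogen and two ring bonds from the ring atom that bears a group of 7 heavy atoms. The two changes are therefore the same kind of change, not the same change.

The expected step from compound 1 to compound 4 in this assay is a step that the limit leaves unreadable from compound 1 to compound 4, resting on compound 1 at its limit > 40000 nM and on the unreadable step that the two limits leave unreadable from compound 3 to compound 2, which give no ground to expect a readable number. Compound 4 is expected to give 60000 nM, between 25000 nM and 150000 nM, most likely again only as a limit.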

Compound 4, half-maximal inhibitory concentration: > 40000 nM
Compound 4 was reported as a limit; the forecaster's own chance of this, stated with the estimate: 85%; the middle value does not contradict the limit.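

Compound 4, like compound 1, is reported only as a limit, so no size can be read for the step between them, and the set stays as it was: the limit of > 40000 nM in this assay, at which 4 of the 4 values shown sit.

The compounds shown leave open whether vinyl in place of ethynyl on an aromatic carbon changes the result in this assay at all, and what number any of the four compounds would give.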